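The source may report more compounds than this note shows. Statements on the series, on what has been measured and on what is new or still open speak of the compounds shown alone.

Measured compounds in the series:

- compound 1, `Cc1ccc(-c2nn(-c3ccc(F)cc3)cc2C(=O)Nc2ccc(C)c(S(=O)(=O)N3CCOCC3)c2)cc1`: 24.3 nM
- compound 2, `COc1cccc(-c2nn(C(C)C)cc2C(=O)Nc2ccc(C)c(S(=O)(=O)N3CCOCC3)c2)c1`: 160 nM
- compound 3, `COc1cccc(Cn2cc(CNc3ccc(C)c(S(=O)(=O)N4CCOCC4)c3)c(C(C)C)n2)c1`: 2310 nM

In an assay on isolated protein for antagonist activity at Bile acid receptor (Homo sapiens), read by TR-FRET, with a stated time of 20 min (a lower number here means a stronger inhibitor, a higher number a weaker inhibitor), compound 1 gives the lowest number of the three. Compound 2 sits at a clearly higher number, and compound 3 is higher again by a wide margin; both gaps lie well beyond the usual scatter, so compound 1 is the strongest inhibitor of the measured set in this assay.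

The next compound, compound 4 `Cc1ccc(-c2nn(-c3ccccc3)cc2C(=O)Nc2ccc(C)c(S(=O)(=O)N3CCOCC3)c2)cc1`, keeps the whole of compound 1 except for one change: hydrogen in place of fluoro on an aromatic carbon, a site para to a large group; cut one bond further out it reads 4-fluorophenyl to phenyl. Among the measured compounds shown here, no pair of measured compounds differs in just this way, so no measured step guides the expectation. Removal of a single fluorine with nothing entering in its place is expected to shift the number in this assay little, if at all: the step from compound 1 to compound 4 is estimated as a 1.3-fold higher number from compound 1 to compound 4 (0.12 log units; within the scatter), a change not beyond the scatter. Compound 4 is therefore expected to give about 32 nM in this assay, in a range from 12 nM to 85 nM.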

Compound 4, half-maximal inhibitory concentration: 47 nM
The estimate for compound 4 lay 1.5-fold (0.17 log units) below the measured number; measured number inside the range.
By their numbers in this assay, from the lowest: compounds 1 and 4 (each within the scatter of the next); then compound 2; then compound 3.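

In this assay, among the compounds shown here, hydrogen in place of fluoro on an aromatic carbon, para to a large group, gives a 1.9-fold higher number from compound 1 to compound 4 (0.29 log units; within the scatter) and is the first one-place comparison available. The 4-fluorophenyl and phenyl compounds therefore cannot be told apart in this assay, and the fluorine is not needed at this site to keep the number at this level. The data on hand offer no explanation for this result.

Going by these compounds, the comparison covers only hydrogen and fluoro, so the effect of chloro, methoxy, an amine or a carboxylic acid at this site remains open. Also open, on these data alone, is whether the same replacement would read the same way elsewhere on the core of compound 1.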